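Phenyl in place of methyl: a forecast for compound 3

A few compounds are considered here, and "the series" means these few. Any claim that something is new, unique, unknown or untested is made for them only; others in the source may bear on it.

In a functional assay (liver) with Rattus norvegicus as the target (on this read-out higher numbers stand for weaker inhibition and lower numbers for stronger inhibition), compound 1 `CC(C)c1nn(-c2ccccc2)c(-c2ccc(F)cc2)c1/C=C/[C@@H](O)C[C@@H](O)CC(=O)O` gives 34 nM. Compound 2 `Cc1cc(-c2ccc(F)cc2)c(/C=C/[C@@H](O)C[C@@H](O)CC(=O)O)c(C(C)C)n1` gives 71 nM, the higher of the two numbers, and the gap lies beyond the scatter. Compound 3 `CC(C)c1nc(-c2ccccc2)cc(-c2ccc(F)cc2)c1/C=C/[C@@H](O)C[C@@H](O)CC(=O)O` has phenyl in place of methyl on an aromatic carbon of compound 2, next to the ring nitrogen: phenyl in place of methyl on an aromatic carbon. Within the data shown here, no measured step isolates this change. Among the measured compounds shown here, the only guide is compound 1, which also carries a phenyl, at 34 nM. A small move toward a lower number is expected in this assay, with an estimated 1.6-fold lower number from compound 2 to compound 3 (0.20 log units; within the scatter). For compound 3 the estimated value is 45 nM, within a range of 15 nM to 140 nM.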

Compound 3, half-maximal inhibitory concentration: 8070 nM
Compound 3: middle estimate off by 180-fold (2.25 log units), on the low side; measured number outside the range, above it.
By their numbers in this assay, from the lowest: compound 1; then compound 2; then compound 3.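

At this carbon, next to the ring nitrogen, this assay tolerates phenyl in place of methyl very poorly, with a 110-fold higher number from compound 2 to compound 3 (2.06 log units; beyond the scatter) as a large step. The phenyl carried by compound 1 therefore offers no guide to this position, since compound 1 differs from compound 3 in more than one place. Nothing at hand accounts for the size of this step.

As far as these compounds go, whether any group beyond methyl gives a similar rise remains open. Ethyl, cyclopropyl or an amine at this carbon would test that.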